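A few compounds are considered here, and "the series" means these few. Any claim that something is new, unique, unknown or untested is made for them only; others in the source may bear on it.

Measured compounds:
- compound 1 `O=c1c(Cc2coc3cccc(OCC4CCCCC4)c3c2=O)coc2ccccc12`: 4230 nM
- compound 2 `Cc1ccc2c(=O)c(Cc3coc4cccc(OCC5CCCCC5)c4c3=O)coc2c1`: 2250 nM
- compound 3 `O=c1c(CCc2coc3ccccc3c2=O)coc2ccccc12`: > 10000 nM

In a functional assay on ACHN cells (Homo sapiens) for antiproliferative activity, read by XTT assay (on this read-out higher numbers stand for weaker inhibition and lower numbers for stronger inhibition), compound 1 gives 4230 nM, the higher of the two numbers read; its nearest neighbour is compound 2, and the step of a 1.9-fold lower number from compound 1 to compound 2 (0.27 log units; within the scatter) lies within the scatter. Compound 3 sits at the limit of > 10000 nM in this assay, at which 1 of the 3 values shown sits, a limit rather than a number. The next compound is compound 4 `CC(C)COc1cccc2occ(Cc3coc4ccccc4c3=O)c(=O)c12`. The change from compound 1 is isopropyl in place of cyclohexyl on a saturated chain carbon bound to an oxygen on an aromatic ring. Among the compounds with values here, no measured step touches this place: the single step recorded, a 1.9-fold lower number from compound 1 to compound 2 (0.27 log units; within the scatter), concerns a different group and is within the scatter, so it gives no direction here. For compound 4 the expectation is a value near that of compound 1, estimated at 5500 nM with a range of 2200 nM to 14000 nM, a step of a 1.3-fold higher number from compound 1 to compound 4 (0.11 log units; within the scatter) that is expected to stay inside the scatter.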

Compound 4, half-maximal inhibitory concentration: 1460 nM
Estimate against measurement, compound 4: 3.8-fold (0.58 log units) above, outside the stated range (below it).
By their numbers in this assay, from the lowest: compounds 4, 2 and 1 (each within the scatter of the next, the first and the last beyond it). At a limit, above all of these: compound 3.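

Isopropyl in place of cyclohexyl on a saturated chain carbon bound to an oxygen on an aromatic ring gives a 2.9-fold lower number from compound 1 to compound 4 (0.46 log units; beyond the scatter), the first step at this place and one beyond the scatter, though modest. This place therefore responds to the group it carries, and the cyclohexyl ring is not needed for activity in this pair. Nothing measured here bears on the cause of this step.

From the compounds shown here alone, how a methyl, a longer chain or an amine at this place would read remains open. Two groups at one place give no trend.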